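A few compounds are considered here, and "the series" means these few. Any claim that something is new, unique, unknown or untested is made for them only; others in the source may bear on it.

In a functional assay on MDA-MB-231 cells (Homo sapiens) for cytotoxicity, read by MTT assay, with a stated time of 72 h (a lower number here means a stronger inhibitor, a higher number a weaker inhibitor), compound 1 `Cc1ccc(NC(=O)CN2CCN(c3nnc(Cc4ccncc4)c4ccccc34)CC2)c(C)c1` gives 240 nM and is the stronger of the two relatives measured so far. Compound 2 `COc1ccc(NC(=O)CN2CCN(c3nnc(Cc4ccccc4)c4ccccc34)CC2)cc1OC` reads 32200 nM as the higher of the two numbers, and the gap between them lies well beyond the usual scatter. Compound 3 `O=C(CN1CCN(c2nnc(Cc3ccccc3)c3ccccc23)CC1)Nc1cc(C(F)(F)F)ccc1Cl` differs from compound 2 on an amide-type nitrogen, where 2-chloro-5-(trifluoromethyl)phenyl comes in place of 3,4-dimethoxyphenyl 2-chloro-5-(trifluoromethyl)phenyl in place of 3,4-dimethoxyphenyl on an amide-type nitrogen while the rest stays the same. For the measured compounds named here, no measured pair shows this change on its own, so any forecast is loose. A lower number, beyond the scatter, is expected, since compound 2 at 32200 nM has much room to fall and compound 1 at 240 nM shows how low a close relative can go. The expected move is an 11-fold lower number from compound 2 to compound 3 (1.03 log units; beyond the scatter) in this estimate. Compound 3 is estimated at 3000 nM within a range of 300 nM to 30000 nM for now.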

Compound 3, half-maximal inhibitory concentration: 19500 nM
For compound 3 the middle estimate is 6.5-fold (0.81 log units) below the measured one, and the stated range covers the measured number.
By their numbers in this assay, from the lowest: compound 1; then compounds 3 and 2 (each within the scatter of the next).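

In this assay, putting 2-chloro-5-(trifluoromethyl)phenyl in place of 3,4-dimethoxyphenyl on an amide-type nitrogen gives a 1.7-fold lower number from compound 2 to compound 3 (0.22 log units; within the scatter), so the two compounds read alike. The two groups share one six-membered aromatic ring of carbon only, yet they differ widely in their atoms: chlorine and fluorine enter, and the oxygen atoms with their 2 hydrogen-bond acceptors leave, with no change in the reading beyond the scatter. No separate measurement bears on this result.

Compound 1, at 240 nM, differs from compound 2 in more than one place, so the compounds shown do not tell which of its differences goes with that value. Also open, from the compounds shown here alone, is how a phenyl ring carrying a carboxylic acid or an amine would read on this nitrogen in this assay.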